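Trimming one methyl from the amide substituent of compound 3

The compounds below may be only part of what the source reports. "The series", "measured", "known", "first", "only" and "open" are said of these compounds alone.

Three compounds share a fluorophenyl-ethynyl arm on a heteroaromatic core that carries an amide. Compound 1 `C[C@@H](NC(=O)c1cnc(C#Cc2cccc(F)c2)nc1)C(C)(C)O` gives 68.7% in a functional assay on HEK293 cells for positive allosteric modulation of metabotropic glutamate receptor 5 (Rattus norvegicus), read by fluorescence and calcium flux; on this read-out lower numbers stand for smaller maximal responses and higher numbers for larger maximal responses. Compound 2 `C[C@@H](NC(=O)c1ccc(C#Cc2cccc(F)c2)cn1)C(C)(C)C` gives 66% in this assay. Its mirror-drawn partner, compound 3 `C[C@H](NC(=O)c1ccc(C#Cc2cccc(F)c2)cn1)C(C)(C)C`, gives 70.8%. Going by the values given here, the step of a number 4.8 percentage points higher from compound 2 to compound 3 (within the scatter) is the only measured step between two compounds that differ in one place, and it rests on (the fact that compounds 2 and 3 differ only in the configuration as drawn); it stays within the scatter. Compound 3 therefore stands among three values that cannot be told apart by this read-out, its two neighbours lying no further from it than repeat measurements would.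

Compound 4 `CC(C)[C@@H](C)NC(=O)c1ccc(C#Cc2cccc(F)c2)cn1` differs from compound 3 by 1,2-dimethylpropyl in place of 1,2,2-trimethylpropyl on an amide-type nitrogen. Among the compounds with values here, no measured step touches the size of the alkyl group on the amide nitrogen; the one available step concerns configuration only and was within the scatter. With nothing in the data pointing either way, the step of a number 2.8 percentage points lower from compound 3 to compound 4 (within the scatter) is expected to stay within the scatter. On that basis compound 4 is estimated to reach 68% in this assay, with a range from 55% to 81%.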

Compound 4, largest response reached (reported as efficacy), in percent of the reference or control that the assay uses: 69.3%
Estimate against measurement, compound 4: 1.3 percentage points below; the range from low to high includes it.
By their numbers in this assay, from the lowest: compounds 2, 1, 4 and 3 (each within the scatter of the next).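

In this assay, the exchange of 1,2,2-trimethylpropyl for 1,2-dimethylpropyl on the amide-type nitrogen gives a number 1.5 percentage points lower from compound 3 to compound 4 (within the scatter), so the maximal response does not distinguish between these two groups at this position. The same holds against the other drawn configuration of the larger group, with a number 3.3 percentage points higher from compound 2 to compound 4 (within the scatter). The loss of this methyl can therefore be read from two starting points, and neither gives a step beyond the scatter, since the two starting compounds form a matched pair: the fact that compounds 2 and 3 differ only in the configuration as drawn

The compounds shown leave open whether a much shorter group such as ethyl, a longer chain, or a chain bearing an amine or a carboxylic acid would keep the maximal response in this range on the amide nitrogen. They also leave open whether the trimmed methyl matters for anything other than the largest response reached, such as the concentration needed to reach it.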